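Fluoro in Place of Methyl on an Anilide Ring

The source may report more compounds than this note shows. Statements on the series, on what has been measured and on what is new or still open speak of the compounds shown alone.

Of the compounds shown here, three sharing one core have been tested in an ADME assay on SW480 cells (Homo sapiens) for cytotoxicity, read by MTT assay, with a stated time of 72 h; on this read-out lower numbers stand for stronger inhibition and higher numbers for weaker inhibition. Compound 1 `CCCCCN1C(=O)C/C(=C\c2cccc(C(=O)Nc3ccc(C)cc3)c2)C1=O` returns only a limit in this assay, > 100000 nM. Compound 2 `Cc1cccc(NC(=O)c2cccc(/C=C3\CC(=O)N(c4ccccc4)C3=O)c2)c1` likewise gives a limit in this assay, > 100000 nM. Compound 3 `COc1cc(NC(=O)c2cccc(/C=C3\CC(=O)N(c4ccccc4)C3=O)c2)cc(OC)c1OC` also comes back as a limit in this assay, > 100000 nM. Compound 2 therefore cannot be placed above or below its neighbours: all that is known is the limit of > 100000 nM in this assay, at which 3 of the 3 values shown sit, and no ordering among the three follows from it.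

Compound 4 `O=C(Nc1cccc(F)c1)c1cccc(/C=C2\CC(=O)N(c3ccccc3)C2=O)c1` has not yet been measured. It differs from compound 2 by fluoro in place of methyl on an aromatic carbon, meta to a large group. For the measured compounds named here, no pair of measured compounds records a step of this kind, so its size is unknown. Because the limit of > 100000 nM in this assay, at which 3 of the 3 values shown sit, holds for every measured value, the account expects the change to produce no step beyond the scatter, in either direction. Compound 4 is thus expected to give about 100000 nM in this assay, with a range from 30000 nM to 300000 nM, and most likely to be reported as a limit again. The expected step is a number no higher from compound 2 to compound 4 (the limit leaves the size open).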

Compound 4, half-maximal inhibitory concentration: > 100000 nM
Compound 4: a limit, no number; the forecaster's own chance of this, stated with the estimate: 80%; the middle value lies on the limit itself.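

In this assay compound 4 gives > 100000 nM, which is a limit and not a number. Compound 2 also gives only a limit, so no step can be read between compound 2 and compound 4. The compounds shown leave open whether any of them has a measurable value in this assay.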